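The source may hold more compounds than are shown below. What is called first, only, known or untested is meant among the compounds shown, and "the series" means these compounds.

In a functional assay on M21 cells (Homo sapiens) for antiproliferative activity, read by sulforhodamine B assay, with a stated time of 48 h (on this read-out lower numbers stand for stronger inhibition and higher numbers for weaker inhibition), compound 1 `O=C1NCCN1c1ccc(S(=O)(=O)Nc2cccc(Br)c2)cc1` gives 59 nM, compound 2 `COc1ccc(NS(=O)(=O)c2ccc(N3CCNC3=O)cc2)cc1` gives 580 nM, and compound 3 `O=C1NCCN1c1ccc(S(=O)(=O)Nc2ccc(F)c(F)c2)cc1` gives 220 nM, the second highest of the three numbers. Compound 3 sits between the other two: the change a 3.7-fold higher number from compound 1 to compound 3 (0.57 log units; beyond the scatter) raised the number, while the change a 2.6-fold lower number from compound 2 to compound 3 (0.42 log units; beyond the scatter) lowered it. Compound 4 `O=C1NCCN1c1ccc(S(=O)(=O)Nc2ccc(I)cc2)cc1` differs from compound 3 in one place: 4-iodophenyl in place of 3,4-difluorophenyl on a sulfonamide nitrogen. Since a ring carrying a single halogen, as in compound 1, comes back, the step of a 3.7-fold higher number from compound 1 to compound 3 (0.57 log units; beyond the scatter) is the nearest guide, and a modestly lower number is expected in this assay, a 2.4-fold lower number from compound 3 to compound 4 (0.39 log units; beyond the scatter). Compound 4 is therefore estimated at 90 nM, with a range from 30 nM to 280 nM.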

Compound 4, half-maximal inhibitory concentration: 260 nM
For compound 4 the middle estimate is 2.9-fold (0.46 log units) below the measured one; low and high end bracket the measured number.
By their numbers in this assay, from the lowest: compound 1; then compounds 3 and 4 (each within the scatter of the next); then compound 2.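

In this assay the change to 4-iodophenyl gives a 1.2-fold higher number from compound 3 to compound 4 (0.07 log units; within the scatter) and so shows that a ring carrying a single halogen does not by itself bring the number close to that of compound 1. That gap remains clear in a 4.4-fold higher number from compound 1 to compound 4 (0.64 log units; beyond the scatter) while a 2.2-fold lower number from compound 2 to compound 4 (0.35 log units; beyond the scatter) shows that iodo in place of methoxy still counts on this ring. Nothing available explains these differences. The compounds shown leave open whether bromo itself or its place on the ring sets compound 1 apart, and how an amine or a carboxylic acid on this ring would read.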